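The source may report more compounds than this note shows. Statements on the series, on what has been measured and on what is new or still open speak of the compounds shown alone.

Measured so far in an ADME assay on Vero cells (Chlorocebus sabaeus) for cytotoxicity, read by reporter gene assay, with a stated time of 4 days; a lower number here means a stronger inhibitor, a higher number a weaker inhibitor:
compound 1, `CCCCCCCC(=O)NCC(C)(C)CC1=C(O)C(=O)c2ccccc2C1=O`, 18400 nM;
compound 2, `CCCCCCCCC(=O)NCC(C)(C)CC1=C(O)C(=O)c2ccccc2C1=O`, 16700 nM;
compound 3, `CCCCCCCCCCC(=O)NCC(C)(C)CC1=C(O)C(=O)c2ccccc2C1=O`, 14900 nM.

Compound 3 returns the lowest of the three numbers, yet both gaps to its neighbours, a 1.1-fold lower number from compound 2 to compound 3 (0.05 log units; within the scatter) and a 1.2-fold lower number from compound 1 to compound 3 (0.09 log units; within the scatter), lie within the scatter, so the three compounds cannot be told apart in this assay. Compound 4, `CCCCCCCCCCCCCC(=O)NCC(C)(C)CC1=C(O)C(=O)c2ccccc2C1=O`, differs from compound 3 by propyl in place of hydrogen on a saturated chain carbon, ten or more bonds along the chain from a carbonyl carbon. The same kind of chain growth has been tried three times: a 1.1-fold lower number from compound 1 to compound 2 (0.04 log units; within the scatter), a 1.2-fold lower number from compound 1 to compound 3 (0.09 log units; within the scatter) and a 1.1-fold lower number from compound 2 to compound 3 (0.05 log units; within the scatter), none of them beyond the scatter. The step from compound 3 to compound 4 is therefore expected to be a 1.1-fold lower number from compound 3 to compound 4 (0.06 log units; within the scatter), at most a slight lowering. Compound 4 is estimated at 13000 nM, within 7000 nM to 26000 nM.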

Compound 4, half-maximal inhibitory concentration: 9810 nM
Estimate against measurement, compound 4: 1.3-fold (0.12 log units) above, within the range that was stated.
By their numbers in this assay, from the lowest: compounds 4, 3, 2 and 1 (each within the scatter of the next).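

In this assay, a 1.5-fold lower number from compound 3 to compound 4 (0.18 log units; within the scatter) comes with propyl in place of hydrogen on a saturated chain carbon, ten or more bonds along the chain from a carbonyl carbon, so growth this far out still does not separate two compounds. The wider spans, a 1.7-fold lower number from compound 2 to compound 4 (0.23 log units; within the scatter) and a 1.9-fold lower number from compound 1 to compound 4 (0.27 log units; within the scatter), also stay within the scatter, so even the pentyl and hexyl differences leave all four compounds indistinguishable. No evidence bears on this result. As far as these compounds go, whether a longer chain would move the number beyond the scatter stays open, as does the outcome with an amine or a carboxylic acid in place of this chain.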